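Swapping a Methyl for a Methoxy on the Sulfonamide Aryl

This account rests on a few compounds, and the source may have more. Where it says the series, first, only, none or still open, it means among the compounds named here.

Measured so far:
- Compound 1 `CS(=O)(=O)Nc1ccc(-c2nc3cc(NS(=O)(=O)c4ccc(Cl)s4)ccc3o2)cc1`: in an assay on cells for inhibition of HSP60/HSP10 (Homo sapiens), with a stated time of 60 min (a lower number here means a stronger inhibitor, a higher number a weaker inhibitor), compound 1 gives 43000 nM.
- Compound 2 `Cc1ccccc1S(=O)(=O)Nc1ccc2oc(-c3ccccc3)nc2c1`: in this assay compound 2 gives > 100000 nM.

The value for compound 2 is a limit of the assay, not a number. For the measured compounds named here, compound 1 and compound 2 differ in several places at once, so no single step between them is computed; what the two values show is that compound 1 returns a number while compound 2 does not (the limit of > 100000 nM in this assay, at which 1 of the 2 values shown sits). Compound 2 therefore stands at the weak end of what this assay can report.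

Compound 3 `COc1cccc(S(=O)(=O)Nc2ccc3oc(-c4ccccc4)nc3c2)c1` arises from compound 2 by one change: 3-methoxyphenyl in place of 2-methylphenyl on a sulfonyl sulfur. Going by the values given here, no measured step of this kind exists among the compounds here, so the expected size and direction of the change rest only on the starting point. With compound 2 sitting at a limit, a modest shift either way would most likely leave compound 3 at or near that limit. Compound 3 is expected to give about 100000 nM, within 30000 nM to 300000 nM. The expected step from compound 2 to compound 3 is a number no higher from compound 2 to compound 3 (the limit leaves the size open), not beyond the scatter.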

Compound 3, half-maximal inhibitory concentration: > 100000 nM
Compound 3 gave a limit, no number; the forecaster's own chance of this, stated with the estimate: 60%; the middle value sits exactly at the limit.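

Compound 2 and compound 3 both sit at a limit of this assay rather than at a number, so the step between them cannot be read. The compounds shown leave open how strongly either one inhibits, and whether 3-methoxyphenyl in place of 2-methylphenyl on a sulfonyl sulfur changes the result at all.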